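A Second Trifluoromethyl on Compound 2

A few compounds are considered here, and "the series" means these few. Any claim that something is new, unique, unknown or untested is made for them only; others in the source may bear on it.

Compound 1 `CC(O)(CS(=O)(=O)c1cc(C(F)(F)F)cc(C(F)(F)F)c1)C(=O)Nc1ccc(S(F)(F)(F)(F)F)cc1`: 15800 nM
Compound 2 `CC(O)(CS(=O)(=O)c1cccc(C(F)(F)F)c1)C(=O)Nc1cccc(S(F)(F)(F)(F)F)c1`: 35500 nM

Within the data shown here, only two compounds have numbers so far. In a functional assay on VCaP cells (Homo sapiens) for antiproliferative activity, read by propidium iodide staining, with a stated time of 96 h (on this read-out higher numbers stand for weaker inhibition and lower numbers for stronger inhibition), compound 2 gives 35500 nM as the higher of the two numbers, which makes it the weaker inhibitor. Its nearest neighbour is compound 1 at 15800 nM on the same read-out, and the gap between them lies beyond the scatter.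

Compound 3 `CC(O)(CS(=O)(=O)c1cc(C(F)(F)F)cc(C(F)(F)F)c1)C(=O)Nc1cccc(S(F)(F)(F)(F)F)c1` has not yet been measured. It departs from compound 2 by a single change (trifluoromethyl in place of hydrogen on an aromatic carbon), with trifluoromethyl in place of hydrogen on an aromatic carbon, meta to a large group and meta to a trifluoromethyl group. Among the measured compounds shown here, no measured pair shows this change alone, so the data give no direct size for it. For the measured compounds named here, the only guide is the narrow span of numbers, whose lower end is set by compound 1 at 15800 nM in this series. The expected step (a 1.8-fold lower number from compound 2 to compound 3 (0.25 log units; within the scatter)) is small, toward a lower number in this assay and stronger inhibition, and it may not clear the scatter. For compound 3 the estimated value is 20000 nM with an expected range from 8000 nM to 45000 nM on this read-out.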

Compound 3, half-maximal inhibitory concentration: 10400 nM
For compound 3 the middle estimate is 1.9-fold (0.28 log units) above the measured one, and the stated range covers the measured number.
By their numbers in this assay, from the lowest: compounds 3 and 1 (each within the scatter of the next); then compound 2.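

The trifluoromethyl group on an aromatic carbon, meta to a large group and meta to a trifluoromethyl group, now has a measured size of its own: in this assay the change gives a 3.4-fold lower number from compound 2 to compound 3 (0.53 log units; beyond the scatter), which could not be read before, as compound 1 and compound 2 differ in more than one place. The exchange of the group on the amide-type nitrogen gives a 1.5-fold lower number from compound 1 to compound 3 (0.18 log units; within the scatter), so with this second trifluoromethyl present, the two forms of that group cannot be told apart on this read-out. No measurement at hand accounts for either step.

The compounds shown leave open whether the trifluoromethyl step carries over to the other form of the group on the amide-type nitrogen, and how this position responds to other groups, such as a nitrile, a chlorine atom or a methoxy group. They also leave open what an amine in place of the hydroxyl group of the shared core would do in this assay.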